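Replacing phenethyl with ethynyl: notes on compound 3

The compounds below may be only part of what the source reports. "The series", "measured", "known", "first", "only" and "open" are said of these compounds alone.

Measured in a functional assay for inhibition, with Homo sapiens as the target; a higher number here means a weaker inhibitor, a lower number a stronger inhibitor:
- Compound 1 `C[C@H](CC(=O)O)NC(=O)CN1CCc2ccc(N3CCNCC3)cc2C1=O`: 30 nM
- Compound 2 `O=C(O)C[C@@H](CCc1ccccc1)NC(=O)CN1CCc2ccc(N3CCNCC3)cc2C1=O`: 16 nM

Among the measured compounds shown here, compound 2 stands within the scatter of compound 1, the only other measured number. Compound 3 `C#C[C@H](CC(=O)O)NC(=O)CN1CCc2ccc(N3CCNCC3)cc2C1=O` carries ethynyl in place of phenethyl on a saturated chain carbon bound to an amide-type nitrogen and a saturated chain carbon. For the measured compounds named here, the one measured step bearing on this is a 1.9-fold lower number from compound 1 to compound 2 (0.27 log units; within the scatter), which also alters the group on this carbon and stays within the scatter. No step beyond the scatter is therefore expected in this assay. The expected step is a 1.6-fold higher number from compound 2 to compound 3 (0.19 log units; within the scatter). Compound 3 is estimated at 25 nM, with an expected range of 9 nM to 70 nM.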

Compound 3, half-maximal inhibitory concentration: 12 nM
Estimate against measurement, compound 3: 2.1-fold (0.32 log units) above, and the stated range covers the measured number.
By their numbers in this assay, from the lowest: compounds 3, 2 and 1 (each within the scatter of the next, the first and the last beyond it).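

In this assay this carbon accepts ethynyl in place of phenethyl, with a 1.3-fold lower number from compound 2 to compound 3 (0.12 log units; within the scatter) despite the loss of the aromatic ring. Ethynyl in place of methyl gives a 2.5-fold lower number from compound 1 to compound 3 (0.40 log units; beyond the scatter) and is the first change at this carbon to pass the scatter, though only modestly. Nothing available gives a reason for either step.

Going by these compounds, whether this step belongs to the triple bond itself stays open, and an ethyl or vinyl group on this carbon would bear on that. A nitrile or an aminomethyl group here also remains untested in the compounds shown.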